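The source may report more compounds than this note shows. Statements on the series, on what has been measured and on what is new or still open speak of the compounds shown alone.

Working notes on the series. All compounds share one core carrying a furanyl group and a variable amino substituent. In an assay on CHO cells for displacement of a labelled ligand from adenosine receptor A1 (Homo sapiens) (a higher number here means a weaker inhibitor, a lower number a stronger inhibitor), compound 1 `COc1ccc(CNc2ncc(C(=O)O)c3nc(-c4ccco4)nn23)cc1OC` gives 958 nM. In this assay compound 2 `CNC(=O)c1cnc(NC(=O)NC2CCCCC2)n2nc(-c3ccco3)nc12` gives 8990 nM. In this assay compound 3 `CCOC(=O)c1cnc(NCc2ccc(F)cc2)n2nc(-c3ccco3)nc12` gives 932 nM. Among these three numbers compound 3 shows the lowest value; its gap to compound 1 is within the scatter, so the two cannot be ordered, whereas its gap to compound 2 is beyond the scatter.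

Compound 4 `CCOC(=O)c1cnc(NC2CCCCC2)n2nc(-c3ccco3)nc12` awaits measurement. It differs from compound 3 by cyclohexyl in place of 4-fluorobenzyl on a nitrogen on an aromatic ring. Within the data shown here, no measured pair in this set isolates that change, so its size is not fixed by the data. Compound 2 also carries a cyclohexyl group, on a urea rather than directly on the ring nitrogen, and differs in a second place as well, so its number only hints that a cyclohexyl-bearing compound can sit at a high value. A modest step toward a higher number, or none beyond the scatter, is expected; the expected step from compound 3 to compound 4 in this assay is a 1.7-fold higher number from compound 3 to compound 4 (0.23 log units; within the scatter). Compound 4 is estimated at 1600 nM, with a range from 400 nM to 6500 nM.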

Compound 4, inhibition constant: 141 nM
Beside the measured number, compound 4's estimate is 11-fold (1.05 log units) above it; the whole stated range lies above it.
By their numbers in this assay, from the lowest: compound 4; then compounds 3 and 1 (each within the scatter of the next); then compound 2.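

In this assay, replacing 4-fluorobenzyl with cyclohexyl on a nitrogen on an aromatic ring gives a 6.6-fold lower number from compound 3 to compound 4 (0.82 log units; beyond the scatter). Among these compounds, this is the first pair to isolate this position, and it shows that the amino substituent alone can move the number beyond the scatter while the rest of compound 3 stays fixed. The change removes the aromatic ring and the fluorine together and also alters the group's size, and nothing available explains the step.

This single pair leaves open which of those differences carries the step, a question that unsubstituted benzyl, phenyl or cyclopentyl on the same nitrogen would help to separate. It also leaves open whether an open chain such as n-hexyl would match cyclohexyl, and whether the step holds on other cores.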